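The source may report more compounds than this note shows. Statements on the series, on what has been measured and on what is new or still open speak of the compounds shown alone.

Measured so far:
- compound 1 `CCN(Cc1ccccc1)c1cc(C)nc(N(CC)c2ccc(C(C)C)cc2Br)n1` — 17 nM
- compound 2 `CCCCN(CC)c1nc(C)nc(N(CC)c2ccc(OC(F)(F)F)cc2Br)n1` — 5 nM
- compound 3 `CCN(c1ccc(C(C)C)cc1)c1nc(C)cc(C)n1` — a limit, > 1000 nM

In an assay on isolated protein for binding affinity to corticotropin-releasing factor receptor 1 (Homo sapiens) (on this read-out higher numbers stand for weaker inhibition and lower numbers for stronger inhibition), compound 1 gives 17 nM. Of the two numbers shown, compound 1 has the higher one; compound 2, with 5 nM, sits lower by a gap that is beyond the usual scatter. The value for compound 3 is a limit of the assay, not a number (the limit of > 1000 nM in this assay, at which 1 of the 3 values shown sits), so it cannot be placed against the other two.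

Compound 4 `CCCN(c1cc(C)nc(N(CC)c2ccc(C(C)C)cc2Br)n1)C1CC1` is compound 1 with a single change: cyclopropyl(propyl)amino in place of benzyl(ethyl)amino on an aromatic carbon. For the measured compounds named here, only compound 1 and compound 4 share this core, so no measured step of the same kind is available; what can be drawn on is that compound 2, which carries a short open-chain dialkylamino group on a related core, gives 5 nM.

For compound 4 the expected step from compound 1 is a 1.7-fold lower number from compound 1 to compound 4 (0.23 log units; within the scatter), a small shift towards a lower number, and not clearly beyond the scatter. The estimate for compound 4 in this assay is 10 nM, with a plausible range from 3 nM to 40 nM.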

Compound 4, inhibition constant: 5 nM
Beside the measured number, compound 4's estimate is 2.0-fold (0.30 log units) above it; the measured number falls inside the stated range.
By their numbers in this assay, from the lowest: compounds 2 and 4 (each within the scatter of the next); then compound 1. At a limit, above all of these: compound 3.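

Swapping benzyl(ethyl)amino for cyclopropyl(propyl)amino at this position on the shared core gives the first readable step in this assay (a 3.4-fold lower number from compound 1 to compound 4 (0.53 log units; beyond the scatter)), so the six-membered aromatic ring of the benzyl group is not required for a value in this range, and a group with fewer heavy atoms is accepted here. The change touches both substituents on the amino nitrogen at once, with benzyl giving way to cyclopropyl and ethyl to propyl, so this one step cannot be divided between the two. Nothing in the data at hand accounts for the step.

Still open, as far as these compounds go, is which part of the swap carries the step: cyclopropyl(ethyl)amino and benzyl(propyl)amino at this position would separate the two when set against compound 1 and compound 4. Also open, from the compounds shown here alone, is how far this position tolerates other kinds of group, such as a morpholine ring, a hydroxyethyl chain or a longer open-chain dialkylamino group.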